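Moving the formyl group: from compound 3 to compound 4

The compounds below may be only part of what the source reports. "The series", "measured", "known", "first", "only" and "open" are said of these compounds alone.

Of the compounds shown here, three have been measured in a functional assay on HT-29 cells (Homo sapiens) for cytotoxicity, read by MTT assay, with a stated time of 24 h; on this read-out lower numbers stand for stronger inhibition and higher numbers for weaker inhibition. Compound 1 `C#CCOc1cc(N(CC)CC)ccc1/C=N/Cc1ccc(S(N)(=O)=O)cc1` gives 62800 nM in this assay, and compound 2 `C#CCOc1ccc(Br)cc1/C=N/Cc1ccc(S(N)(=O)=O)cc1` gives 45700 nM. Going by the values given here, compound 3 `O=Cc1ccccc1OCc1cn(CCCOc2ccc3ccc(=O)oc3c2)nn1` gives 18900 nM, the lowest of the three numbers; its gap to compound 2 and its larger gap to compound 1 both lie beyond the scatter of repeated measurements, so compound 3 is the most potent of the three compounds measured so far.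

Compound 4 `O=Cc1cccc(OCc2cn(CCCOc3ccc4ccc(=O)oc4c3)nn2)c1` is built from the same atoms as compound 3, joined differently: 3-formylphenyl in place of 2-formylphenyl on an oxygen on a saturated carbon. Among the compounds with values here, nothing else in the molecule is altered, and no measured pair in this set shows the effect of such a positional change, so there is no step to lean on. The change is small in count, and the expectation is for a modest shift, if any, in this assay, with no firm direction: the step from compound 3 to compound 4 is estimated as a 1.3-fold higher number from compound 3 to compound 4 (0.12 log units; within the scatter), which may well fall within the scatter. Compound 4 is therefore expected to give about 25000 nM in this assay, with a plausible range from 8000 nM to 80000 nM.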

Compound 4, half-maximal inhibitory concentration: 129000 nM
Beside the measured number, compound 4's estimate is 5.2-fold (0.71 log units) below it, outside the stated range (above it).
By their numbers in this assay, from the lowest: compound 3; then compounds 2 and 1 (each within the scatter of the next); then compound 4.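

In this assay, the place of the formyl group proves to matter: a 6.8-fold higher number from compound 3 to compound 4 (0.83 log units; beyond the scatter), a step beyond the scatter, even though the two compounds are built from the same atoms and the counts of heavy atoms, double bonds and hydrogen-bond acceptors in the exchanged group do not change. Going by these compounds alone, this is the only step in the set that can be read between compounds differing in one place, and it shows that, on an oxygen on a saturated carbon, 2-formylphenyl gives the lower number of the two arrangements, so the read-out here responds to how the group is joined and not only to which atoms are present. Nothing available accounts for a step of this size.

A single pair cannot show whether this order would carry over to other groups, such as a carboxylic acid or a nitrile in place of the formyl group. The compounds shown also leave open whether the same step would appear with a longer chain linking the two parts of the molecule.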